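Swapping a Fluoro Acid Group on Compound 2

The source may report more compounds than this note shows. Statements on the series, on what has been measured and on what is new or still open speak of the compounds shown alone.

In an ADME assay on the whole organism (Rattus norvegicus, strain Sprague-Dawley) for pharmacokinetics, read by LC-MS (a higher number here means faster removal of the compound, a lower number slower removal), compound 1 `COc1ccc(F)c([C@H]2CC[C@H](COc3cccc([C@@H](CC(=O)O)C4CC4)c3)CC2)c1` gives 0.4 mL/min/kg and compound 2 `COc1ccc(F)c([C@H]2CC[C@H](COc3cccc([C@H](C4CC4)[C@@H](F)C(=O)O)c3)CC2)c1` gives 2.7 mL/min/kg as the higher of the two numbers. Within the data shown here, compound 3 `COc1ccc(F)c([C@H]2CC[C@H](COc3cccc([C@H](C4CC4)[C@@](C)(F)C(=O)O)c3)CC2)c1` brings 1-carboxy-1-fluoroethyl in place of carboxy(fluoro)methyl on a saturated chain carbon bound to an aromatic carbon and a saturated ring carbon as its one change from compound 2. Among the measured compounds shown here, the only measured step is a 6.8-fold higher number from compound 1 to compound 2 (0.83 log units; beyond the scatter) for fluoro in place of hydrogen, a different exchange, so it guides this one only loosely. No step beyond the scatter is therefore expected, and the estimated change is a 1.4-fold lower number from compound 2 to compound 3 (0.13 log units; within the scatter) with wide uncertainty. For compound 3 the estimate is 2 mL/min/kg within an expected range from 0.6 mL/min/kg to 6 mL/min/kg for this read-out.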

Compound 3, clearance: 17 mL/min/kg
The estimate for compound 3 lay 8.5-fold (0.93 log units) below the measured number; measured number above the stated range.
By their numbers in this assay, from the lowest: compound 1; then compound 2; then compound 3.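

In this assay, 1-carboxy-1-fluoroethyl in place of carboxy(fluoro)methyl gives a 6.3-fold higher number from compound 2 to compound 3 (0.80 log units; beyond the scatter), so this position stays sensitive even after the fluoro is in place. Set against carboxymethyl, the same group gives a 43-fold higher number from compound 1 to compound 3 (1.63 log units; beyond the scatter), the largest step shown here. No evidence here explains these rises.

Still open, on these data alone, is whether 1-carboxyethyl, without the fluoro, would move the number the same way. Also open, as far as these compounds go, is whether a longer chain such as 1-carboxy-1-fluoropropyl would move it further.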